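The source may hold more compounds than are shown below. What is called first, only, known or untested is meant among the compounds shown, and "the series" means these compounds.

Of the compounds shown here, two built on a shared core have been tested in a functional assay on SNB-19 cells (Homo sapiens) for cytotoxicity, read by sulforhodamine B assay, with a stated time of 48 h, tested at 0.1 uM; a higher number here means a weaker effect of the compound at the concentration tested, a lower number a stronger effect. Compound 1 `COc1ccc(-c2cc(/C=C/C(=O)c3ccc(N)cc3)[nH]n2)cc1` gives 89% in this assay. Compound 2 `COc1cc(-c2cc(/C=C/C(=O)c3ccc(N)cc3)[nH]n2)cc(OC)c1OC` gives 94% in this assay. Among the compounds with values here, of the two numbers, the one for compound 2 is the higher, but its gap to compound 1 lies within the usual scatter of such measurements, so the two cannot be told apart. Both numbers show that, at the concentration tested, neither compound does much to the cells.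

Compound 3 `COc1cc(-c2cc(/C=C/C(=O)c3ccc(Cl)c(Cl)c3)[nH]n2)cc(OC)c1OC` has not yet been measured. It differs from compound 2 in one place: 3,4-dichlorophenyl in place of 4-aminophenyl on a carbonyl carbon. Within the data shown here, no step between measured compounds covers such a change, so the expectation rests on the values alone. Because compound 2 gives 94%, a number already near the top of the scale, the step is expected to be a number 4 percentage points lower from compound 2 to compound 3 (within the scatter), small and not beyond the scatter in either direction. Compound 3 is therefore expected to give about 90% in this assay. The estimated range for compound 3 runs from 75% to 102%.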

Compound 3, a percentage reported as activity, at one concentration (the size of the read-out at that concentration, not a potency): 92%
Estimate against measurement, compound 3: 2 percentage points below; the range from low to high includes it.
By their numbers in this assay, from the lowest: compounds 1, 3 and 2 (each within the scatter of the next).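

Within the data shown here, this is the first change at the aryl group on the carbonyl carbon, as the earlier compounds differed only on the other side of the shared core. In this assay, putting 3,4-dichlorophenyl in place of 4-aminophenyl gives a number 2 percentage points lower from compound 2 to compound 3 (within the scatter), so this exchange leaves the read-out indistinguishable, even though the hydrogen-bond donor and acceptor counted on 4-aminophenyl are absent from 3,4-dichlorophenyl and the two groups differ in their heavy atoms. Among these compounds, nothing is available that would explain this outcome, and with both compounds showing so little effect at this single concentration, the result says only that the exchange does not produce a measurable effect here.

The compounds shown leave open whether any group on this carbonyl carbon, such as a carboxylic acid, a morpholine or a longer alkyl chain, would move the read-out beyond the scatter. They also leave open whether compound 2 and compound 3 would separate at a concentration where the cells respond more strongly.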